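Swapping the triazole substituent: sulfonamide in place of methoxyphenyl

A few compounds are considered here, and "the series" means these few. Any claim that something is new, unique, unknown or untested is made for them only; others in the source may bear on it.

Measured compounds:
- compound 1, `Cc1ccc(S(=O)(=O)NCc2cn(C[C@H](O)[C@H]3OC(=O)C(OCc4ccccc4)=C3OCc3ccccc3)nn2)cc1`: 14400 nM
- compound 2, `O=C1O[C@H]([C@@H](O)Cn2cc(-c3cccc(O)c3)nn2)C(OCc2ccccc2)=C1OCc1ccccc1`: 39300 nM
- compound 3, `COc1ccc(-c2cn(C[C@H](O)[C@H]3OC(=O)C(OCc4ccccc4)=C3OCc3ccccc3)nn2)cc1`: 16400 nM

In a functional assay on HeLa cells (Homo sapiens) for antiproliferative activity, read by MTT assay, with a stated time of 72 h (a lower number here means a stronger inhibitor, a higher number a weaker inhibitor), compound 3 stands second highest of the three numbers; compound 1 is within the scatter of it, while compound 2 lies beyond, as a 2.4-fold lower number from compound 2 to compound 3 (0.38 log units; beyond the scatter) shows. Compound 4, `O=C1O[C@H]([C@@H](O)Cn2cc(CNS(=O)(=O)c3ccc(Cl)cc3)nn2)C(OCc2ccccc2)=C1OCc1ccccc1`, differs from compound 3 by (((4-chlorophenyl)sulfonyl)amino)methyl in place of 4-methoxyphenyl on an aromatic carbon. The step that bears on this is a 1.1-fold higher number from compound 1 to compound 3 (0.06 log units; within the scatter), which was within the scatter; the incoming group resembles that of compound 1 closely. So no step beyond the scatter is expected for a 1.2-fold lower number from compound 3 to compound 4 (0.07 log units; within the scatter). Compound 4 is therefore expected to give about 14000 nM, with a range from 7000 nM to 28000 nM.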

Compound 4, half-maximal inhibitory concentration: 13600 nM
Compound 4: middle estimate off by 1.0-fold (0.01 log units), on the high side; measured number inside the range.
By their numbers in this assay, from the lowest: compounds 4, 1 and 3 (each within the scatter of the next); then compound 2.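

In this assay, chloro in place of methyl on the sulfonyl-bound phenyl ring makes no change beyond the scatter, with a 1.1-fold lower number from compound 1 to compound 4 (0.02 log units; within the scatter) as the step. The chlorinated sulfonamide arm also matches 4-methoxyphenyl, giving a 1.2-fold lower number from compound 3 to compound 4 (0.08 log units; within the scatter) as the step, so two quite different groups at this position read alike. Against the 3-hydroxyphenyl group, a 2.9-fold lower number from compound 2 to compound 4 (0.46 log units; beyond the scatter) is a modest step, which leaves compound 2 alone among these four as the weaker inhibitor.

From the compounds shown here alone, whether an amine or a carboxylic acid at this position would shift the number remains open. No measurement here explains why compound 2 stands apart.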